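This account rests on a few compounds, and the source may have more. Where it says the series, first, only, none or still open, it means among the compounds named here.

Compound 1 `CC1=CC[C@@H]([C@@](C)(O)CCCC(C)(C)NC=S)CC1` carries a thiocarbonyl carbon that bears a hydrogen. In a functional assay on HT-29 cells (Homo sapiens) for cytotoxicity, read by sulforhodamine B assay (on this read-out higher numbers stand for lower toxicity in this test and lower numbers for higher toxicity in this test), compound 1 gives 90300 nM. Compound 2 `CC1=CC[C@@H]([C@@](C)(O)CCCC(C)(C)NC(=S)NN)CC1` carries aminoamino in place of that hydrogen. In this assay compound 2 gives only a limit, > 100000 nM. From the compounds shown here alone, the step of an at least 1.1-fold higher number from compound 1 to compound 2 (0.04 log units; that floor lies within the scatter) is bounded by the limit of > 100000 nM in this assay, at which 1 of the 2 values shown sits, so its true size is unknown. Compound 3 `CC1=CC[C@@H]([C@@](C)(O)CCCC(C)(C)NC(=S)N/N=C\c2ccccc2)CC1` differs from compound 2 by a group of 8 heavy atoms (7 carbon, 1 nitrogen; one six-membered aromatic ring of carbon only) in place of one nitrogen atom, on an amide-type nitrogen. Among the measured compounds shown here, only that one measured step bears on this change, and it tells little. For compound 3 in this assay a weak effect is expected, estimated at 70000 nM with a range from 25000 nM to 200000 nM. That estimate means a step of an at least 1.4-fold lower number from compound 2 to compound 3 (0.15 log units; that floor lies within the scatter).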

Compound 3, concentration lethal to 50% of the cells: 57400 nM
Compound 3: the middle estimate sits 1.2-fold (0.09 log units) above what was measured; the range from low to high includes it.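

The aromatic ring on this amide-type nitrogen brings a second exact number to the series: in this assay, the comparison with the thiocarbonyl compound bearing only a hydrogen is a 1.6-fold lower number from compound 1 to compound 3 (0.20 log units; within the scatter). So this much larger group leaves the read-out no further from compound 1 than repeat measurements would. Compound 2 gives only a limit, and the step of an at least 1.7-fold lower number from compound 2 to compound 3 (0.24 log units; that floor lies within the scatter) has an unknown true size because of it: the limit of > 100000 nM in this assay, at which 1 of the 3 values shown sits.

From the compounds shown here alone, whether a chlorine or methoxy group on the ring would shift the read-out beyond the scatter stays open. So does the effect of a saturated cyclohexyl ring or a longer carbon chain in its place.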